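Phenyl in place of isopropyl: what to expect

The source may report more compounds than this note shows. Statements on the series, on what has been measured and on what is new or still open speak of the compounds shown alone.

Of the compounds shown here, three sharing one core have been measured in a functional assay (mast cells) for inhibition, with Rattus norvegicus as the target; on this read-out lower numbers stand for an effect already at smaller amounts and higher numbers for an effect only at larger amounts of compound. Compound 1 `CC1CC/C(=N\Nc2ccc(Br)cc2)c2ncc(C(=O)O)c(=O)n21` gives 2000 nM, compound 2 `Cc1ccc(N/N=C2\CCC(C)n3c2ncc(C(=O)O)c3=O)cc1` gives 280 nM, and compound 3 `CC(C)c1ccc(N/N=C2\CCC(C)n3c2ncc(C(=O)O)c3=O)cc1` gives 1200 nM. Compound 3 thus stands close to compound 1, with a 1.7-fold lower number from compound 1 to compound 3 (0.22 log units; within the scatter), while the comparison with compound 2 shows a 4.3-fold higher number from compound 2 to compound 3 (0.63 log units; beyond the scatter).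

Compound 4 `CC1CC/C(=N\Nc2ccc(-c3ccccc3)cc2)c2ncc(C(=O)O)c(=O)n21` carries phenyl in place of isopropyl on an aromatic carbon, para to a large group: phenyl in place of isopropyl on an aromatic carbon. Going by the values given here, no phenyl compound has been measured, so the evidence is indirect and comes from the three groups at this place. Bromo in compound 1 and isopropyl in compound 3 agree within the scatter, and only methyl in compound 2 departs from them, with a 7.1-fold lower number from compound 1 to compound 2 (0.85 log units; beyond the scatter) and the step to compound 3 given above. Compound 4 is expected to stay with compound 1 and compound 3, so no step beyond the scatter is expected, and the estimate is a 1.3-fold higher number from compound 3 to compound 4 (0.10 log units; within the scatter). For compound 4 the estimated value is 1500 nM, with an expected range of 450 nM to 5000 nM.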

Compound 4, half-maximal effective concentration: 4400 nM
Compound 4: middle estimate off by 2.9-fold (0.47 log units), on the low side; low and high end bracket the measured number.
By their numbers in this assay, from the lowest: compound 2; then compounds 3 and 1 (each within the scatter of the next); then compound 4.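

In this assay, going by these compounds alone, phenyl is the first group at this place to part from both bromo and isopropyl, which had agreed within the scatter: the result gives a 3.7-fold higher number from compound 3 to compound 4 (0.56 log units; beyond the scatter) and also a 2.2-fold higher number from compound 1 to compound 4 (0.34 log units; beyond the scatter), so that agreement does not extend to phenyl. Measured against methyl, the change is larger still, with a 16-fold higher number from compound 2 to compound 4 (1.20 log units; beyond the scatter), which makes this the widest step among the four groups and places compound 2 and compound 4 at the two ends of the series. Nothing available gives a reason for the rise with phenyl.

The compounds shown leave open where ethyl, methoxy or an amine at this place would fall, nearer compound 2 or nearer compound 4. They also leave open whether a pyridine ring in place of phenyl would give a number as high as that of compound 4.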